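Chloro in place of hydrogen on the phenyl ring

A few compounds are considered here, and "the series" means these few. Any claim that something is new, unique, unknown or untested is made for them only; others in the source may bear on it.

Compound 3 `C=C1CC(COc2cc(C(=O)O)n(C)n2)(c2ccccc2)OC1=O` carries the shared core with an unsubstituted phenyl group. In a functional assay on L1210 cells (Mus musculus) for antiproliferative activity (a lower number here means a stronger inhibitor, a higher number a weaker inhibitor), compound 3 gives > 10000 nM, which is a limit of the assay and not a number. Compound 2 `C=C1CC(COc2cc(C(=O)O)n(C)n2)(c2ccc(-c3ccccc3)cc2)OC1=O` bears a phenyl in place of that hydrogen on the aromatic carbon. In this assay compound 2 gives > 10000 nM, again a limit rather than a number. The step that the two limits leave unreadable from compound 2 to compound 3 is therefore unreadable in size; the limit of > 10000 nM in this assay, at which 2 of the 3 values shown sit, marks where both sit. Going by the values given here, compound 1 `C=C(Br)C(=O)Nc1ccc2sc(C(=O)NCCNC(=O)c3cc(OCC4(c5ccc(Cl)cc5)CC(=C)C(=O)O4)nn3C)cc2c1` is a far larger molecule that contains a 4-chlorophenyl within it, and in this assay compound 1 gives 260 nM; no step between it and the small acids is defined.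

Compound 4 `C=C1CC(COc2cc(C(=O)O)n(C)n2)(c2ccc(Cl)cc2)OC1=O` differs from compound 3 by chloro in place of hydrogen on an aromatic carbon. Among the compounds with values here, no measured step bears directly on this change: the one step measured between the small acids is unreadable because of the limit of > 10000 nM in this assay, at which 2 of the 3 values shown sit. Compound 3 stands at the limit, so the expected step that the limit leaves unreadable from compound 3 to compound 4 cannot be placed on either side of the scatter with confidence, and a value at the limit again is the most likely outcome. Compound 4 is estimated at 15000 nM, with a range from 3000 nM to 50000 nM.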

Compound 4, half-maximal inhibitory concentration: > 10000 nM
Compound 4 gave a limit, no number; the forecaster's own chance of this, stated with the estimate: 75%; the middle value does not contradict the limit.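

No new step can be read among compound 2, compound 3 and compound 4 in this assay, since all three stand at a limit of the assay and not at a number: the limit of > 10000 nM in this assay, at which 3 of the 4 values shown sit.

The compounds shown leave open whether chloro or phenyl in place of hydrogen on the phenyl ring has any effect on these small acids, and which part of compound 1 separates it from them.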